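Pyrrolidine to methylpiperazine on an amine-bearing chain

A few compounds are considered here, and "the series" means these few. Any claim that something is new, unique, unknown or untested is made for them only; others in the source may bear on it.

Of the compounds shown here, three on a shared core have been measured in an ADME assay on L6 cells (Rattus norvegicus) for cytotoxicity, read by resazurin assay, with a stated time of 72 h; a lower number here means a stronger inhibitor, a higher number a weaker inhibitor. Compound 1 `CN1CCN(CCC(=O)N2CC3C(c4ccccc4)CC(N(C)C)(CC3c3ccccc3)C2)CC1` gives 13000 nM, compound 2 `CN(C)C12CC(c3ccccc3)C(CN(C(=O)CCN3CCCC3)C1)C(c1ccccc1)C2` gives 11700 nM, and compound 3 `CN(C)C12CC(c3ccccc3)C(CN(CCN3CCCC3)C1)C(c1ccccc1)C2` gives 5580 nM. Compound 2 and compound 1 differ by 4-methylpiperazin-1-yl in place of pyrrolidin-1-yl on a saturated chain carbon, two bonds along the chain from a carbonyl carbon, and the step is a 1.1-fold higher number from compound 2 to compound 1 (0.05 log units; within the scatter). The two cores of compound 2 and compound 3 differ by 2-(pyrrolidin-1-yl)ethyl in place of (2-(pyrrolidin-1-yl)ethyl)carbonyl on an amine nitrogen in a ring, with the step of a 2.1-fold lower number from compound 2 to compound 3 (0.32 log units; beyond the scatter); the step of a 2.3-fold lower number from compound 1 to compound 3 (0.37 log units; beyond the scatter) is of similar size, so compound 3 stands lowest of the three.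

Compound 4 `CN1CCN(CCN2CC3C(c4ccccc4)CC(N(C)C)(CC3c3ccccc3)C2)CC1` is not yet measured and differs from compound 3 by 4-methylpiperazin-1-yl in place of pyrrolidin-1-yl on a saturated chain carbon, two bonds along the chain from an amine nitrogen in a ring. This is the same kind of change as from compound 2 to compound 1, though the place differs: there the saturated chain carbon sits two bonds along the chain from a carbonyl carbon, here two bonds along the chain from an amine nitrogen in a ring. Because the earlier step of a 1.1-fold higher number from compound 2 to compound 1 (0.05 log units; within the scatter) lay within the scatter, the step from compound 3 to compound 4 is expected to be a 1.1-fold higher number from compound 3 to compound 4 (0.05 log units; within the scatter). Compound 4 is therefore estimated at 6200 nM, with a likely range from 3000 nM to 13000 nM.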

Compound 4, half-maximal inhibitory concentration: 5260 nM
Compound 4: middle estimate off by 1.2-fold (0.07 log units), on the high side; measured number inside the range.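

The exchange of pyrrolidin-1-yl for 4-methylpiperazin-1-yl gives a 1.1-fold lower number from compound 3 to compound 4 (0.03 log units; within the scatter), and in this assay it reads alike on the chains with and without the carbonyl: the same change on two cores in this assay, a 1.1-fold higher number (0.05 log units; within the scatter) from compound 2 to compound 1 and a 1.1-fold lower number (0.03 log units; within the scatter) from compound 3 to compound 4, 1.2-fold (0.07 log units) apart, within the scatter of two such steps The steps from the carbonyl compounds lie beyond the scatter whichever terminal ring is present, with a 2.2-fold lower number from compound 2 to compound 4 (0.35 log units; beyond the scatter) and a 2.5-fold lower number from compound 1 to compound 4 (0.39 log units; beyond the scatter), so among these four compounds the carbonyl, not the terminal ring, goes with the difference in the numbers. This shows that the exchange carries over without a visible step between these two closely related chains in this assay, but two pairs do not show that it would do so on other cores, and a step within the scatter does not prove that the two groups are equivalent.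

The compounds shown leave open whether another terminal amine, such as morpholine or piperidine, or a longer chain leading to that amine would behave the same way. They also leave open whether the exchange would stay this small in any other assay.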